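Replacing an aryl amide with a piperidine amide

This account rests on a few compounds, and the source may have more. Where it says the series, first, only, none or still open, it means among the compounds named here.

Compound 1 `O=C(CCC(=O)OCCCCCCSc1ccc([N+](=O)[O-])c2nonc12)Nc1ccc(F)cc1` carries the shared core and ends in an amide whose nitrogen bears a 4-fluorophenyl group. In a functional assay on A549 cells (Homo sapiens) for inhibition, read by MTT assay, with a stated time of 72 h (a lower number here means a stronger inhibitor, a higher number a weaker inhibitor), compound 1 gives 6300 nM, the highest number among the three measured compounds. Compound 3 `CN(C)CCNC(=O)CCC(=O)OCCCCCCSc1ccc([N+](=O)[O-])c2nonc12` gives 5550 nM, and the step of a 1.1-fold lower number from compound 1 to compound 3 (0.06 log units; within the scatter) stays within the scatter, so the two cannot be ranked. Compound 2 `CN(C)CCCNC(=O)CCC(=O)OCCCCCCSc1ccc([N+](=O)[O-])c2nonc12` gives 1580 nM, and the step of a 4.0-fold lower number from compound 1 to compound 2 (0.60 log units; beyond the scatter) is the only one that moves beyond the scatter; the step of a 3.5-fold higher number from compound 2 to compound 3 (0.55 log units; beyond the scatter) separates these two compounds from each other.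

Compound 4 `O=C(CCC(=O)N1CCCCC1)OCCCCCCSc1ccc([N+](=O)[O-])c2nonc12` is the next compound to be measured. Its difference from compound 1 is this: piperidin-1-yl in place of (4-fluorophenyl)amino on a carbonyl carbon The group that leaves carries 1 hydrogen-bond donor, the group that enters carries none, and no dimethylamino group is present anywhere in compound 4. The measured steps from compound 1 to compound 2 and to compound 3 also remove the 4-fluorophenyl from the amide-type nitrogen, and they gave one modest gain and one change within the scatter. A change no larger than that is expected here, with the number for compound 4 estimated at 5000 nM, within the range 2000 nM to 15000 nM. The expected step is a 1.3-fold lower number from compound 1 to compound 4 (0.10 log units; within the scatter), within the scatter.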

Compound 4, half-maximal inhibitory concentration: 2510 nM
Compound 4: middle estimate off by 2.0-fold (0.30 log units), on the high side, and the stated range covers the measured number.
By their numbers in this assay, from the lowest: compounds 2 and 4 (each within the scatter of the next); then compounds 3 and 1 (each within the scatter of the next).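

In this assay, the step to the piperidin-1-yl amide (a 2.5-fold lower number from compound 1 to compound 4 (0.40 log units; beyond the scatter)) shows that the number can fall beyond the scatter with no dimethylamino group in the molecule and no amide hydrogen, which compounds 2 and 3 could not show because both carry the former and keep the latter. Compound 4 also stands apart from the 2-(dimethylamino)ethyl amide (a 2.2-fold lower number from compound 3 to compound 4 (0.34 log units; beyond the scatter)) but cannot be told from the 3-(dimethylamino)propyl amide (a 1.6-fold higher number from compound 2 to compound 4 (0.20 log units; within the scatter)), so among these four compounds, a dimethylamino group is not needed to reach the lower pair of numbers. No evidence is at hand on why these changes shift the number.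

The step from compound 1 to compound 4 changes the aromatic ring and the amide hydrogen together, so a cyclohexylamino group, which has a non-aromatic ring and keeps that hydrogen, would be needed to tell the two changes apart. From the compounds shown here alone, it also remains open whether a morpholin-4-yl group, or a piperidine ring carrying an amine, would fit on this carbonyl carbon as well as the plain piperidin-1-yl group does.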